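Swapping the aniline for a cyclic amine on the core

The source may report more compounds than this note shows. Statements on the series, on what has been measured and on what is new or still open speak of the compounds shown alone.

Measured so far:
compound 1, `CC1CCC(Nc2nc(C(F)(F)F)ccc2CNC(=O)C(C)c2ccc(NS(C)(=O)=O)c(F)c2)CC1`, 27.2 nM
compound 2, `CC(C(=O)NCc1ccc(C(F)(F)F)nc1N(C)c1ccccc1)c1ccc(NS(C)(=O)=O)c(F)c1`, 0.9 nM

In a functional assay on CHO-K1 cells for antagonist activity at transient receptor potential cation channel subfamily V member 1 (Homo sapiens), read by FLIPR (a higher number here means a weaker inhibitor, a lower number a stronger inhibitor), compound 2 gives the lowest of the two numbers; its nearest neighbour is compound 1, and the step of a 30-fold lower number from compound 1 to compound 2 (1.48 log units; beyond the scatter) was large. Compound 3, `CC(C(=O)NCc1ccc(C(F)(F)F)nc1N1CC=CCC1)c1ccc(NS(C)(=O)=O)c(F)c1`, has not yet been measured. It differs from compound 2 by a group of 6 heavy atoms (5 carbon, 1 nitrogen; one six-membered non-aromatic ring with 1 hetero atom) in place of a group of 8 heavy atoms (7 carbon, 1 nitrogen; one six-membered aromatic ring of carbon only), on an aromatic carbon. Among the measured compounds shown here, the one measured step, from compound 1 to compound 2, touched the same position: there a nitrogen bearing a hydrogen and a non-aromatic ring was replaced by a nitrogen bearing a methyl and a flat aromatic ring, and the number fell sharply. Compound 3 keeps a nitrogen without hydrogen but returns to a non-aromatic ring, so it sits between the two measured cases. For compound 3 a step of a 3.9-fold higher number from compound 2 to compound 3 (0.59 log units; beyond the scatter) is expected, a modest rise. The estimate for compound 3 in this assay is 3.5 nM, between 0.9 nM and 14 nM.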

Compound 3, inhibition constant: 0.3 nM
For compound 3 the middle estimate is 12-fold (1.07 log units) above the measured one, outside the stated range (below it).
By their numbers in this assay, from the lowest: compound 3; then compound 2; then compound 1.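

In this assay the change gives a 3.0-fold lower number from compound 2 to compound 3 (0.48 log units; beyond the scatter), so an aromatic ring is not required on the group next to the ring nitrogen. Among the compounds shown here, the wider comparison gives a 91-fold lower number from compound 1 to compound 3 (1.96 log units; beyond the scatter), which shows that a non-aromatic ring at this position can go with a far lower number than the one seen for compound 1. The gain in compound 3 therefore comes with a non-aromatic ring that contains the attached nitrogen and has one double bond, although several features differ at once, and nothing shown gives a reason for either step.

From the compounds shown here alone, it remains open whether the double bond matters, which a fully saturated piperidin-1-yl group would test. A five-membered pyrrolidin-1-yl group or a morpholin-4-yl group would show how much ring size and a ring oxygen change the number.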